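A few compounds are considered here, and "the series" means these few. Any claim that something is new, unique, unknown or untested is made for them only; others in the source may bear on it.

Compound 2 `N#CC1=C(N)Oc2c(N)cc3nc4ccccc4nc3c2C12C(=O)N(Cc1cnnn1-c1cccc(Br)c1)c1ccccc12` is one of two measured members of a small series tested in an ADME assay on HUVEC cells (Homo sapiens) for antiproliferative activity, read by MTT assay, with a stated time of 48 h; on this read-out higher numbers stand for weaker inhibition and lower numbers for stronger inhibition. In this assay compound 2 gives > 50000 nM, which is a limit of the assay rather than a number. Compound 1 `N#CC1=C(N)Oc2c(c3nc4ccccc4nc3c3ccccc23)C12C(=O)N(Cc1cnnn1-c1ccc(S(N)(=O)=O)cc1)c1ccccc12` is the other measured member. In this assay compound 1 gives > 50000 nM, again a limit of the assay rather than a number. Going by the values given here, compound 2 therefore stands at the same limit as the only other value shown (the limit of > 50000 nM in this assay, at which 2 of the 2 values shown sit), and neither compound yields a number that could be placed above or below the other. Compound 3 `Cc1cc(C)c(-n2nncc2CN2C(=O)C3(C(C#N)=C(N)Oc4c(N)cc5nc6ccccc6nc5c43)c3ccccc32)c(C)c1` has not yet been measured. It differs from compound 2 in a single place: 2,4,6-trimethylphenyl in place of 3-bromophenyl on an aromatic nitrogen. Among the compounds with values here, no step between two measured compounds is available to show how such a change moves the result, so the expectation rests on both measured compounds sitting at the limit. Compound 3 is expected to give 80000 nM, with a plausible range from 30000 nM to 300000 nM, most likely reported again only as a limit. The step that the limit leaves unreadable from compound 2 to compound 3 is expected to be none beyond the scatter, in no particular direction.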

Compound 3, half-maximal inhibitory concentration: > 50000 nM
Compound 3: no number, only a limit (the forecaster's own chance of this, stated with the estimate: 80%); the middle value is on the limit's open side.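

In this assay compound 3 gives > 50000 nM, a limit of the assay and not a number. Compound 2 also stands at a limit, so no step from compound 2 to compound 3 can be read: the limit of > 50000 nM in this assay, at which 3 of the 3 values shown sit.

The compounds shown leave open whether 2,4,6-trimethylphenyl in place of 3-bromophenyl changes the result at all.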